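Adding phenyl to the side chain of compound 2

The source may report more compounds than this note shows. Statements on the series, on what has been measured and on what is new or still open speak of the compounds shown alone.

In a functional assay on the whole organism with Mus musculus as the target (a higher number here means that more compound is needed for the effect, a lower number that less compound is needed), compound 1 (`CN(c1ccncc1)n1cccc1CO`) gives > 20 mg/kg, which is a limit and not a number. Compound 2 (`CCc1cccn1N(C)c1ccncc1`) gives > 20 mg/kg, which is likewise a limit, so its position is bounded on one side only. The data so far amount to the limit of > 20 mg/kg in this assay, at which 2 of the 2 values shown sit. Within the data shown here, the one measured step, a step that the two limits leave unreadable from compound 1 to compound 2, places methyl where hydroxy stood on a saturated chain carbon bound to an aromatic carbon, and it offers no size to carry forward.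

Compound 3 (`CN(c1ccncc1)n1cccc1CCc1ccccc1`) differs from compound 2 by phenyl in place of hydrogen on a saturated chain carbon, two bonds along the chain from an aromatic carbon, which turns methyl into benzyl. Among the measured compounds shown here, no measured step covers a change of this kind, so neither the size nor the direction of the effect can be drawn from the data. The expectation therefore stays close to the limit of compound 2 at > 20 mg/kg, and another limit is the likeliest report. The expected change is a step that the limit leaves unreadable from compound 2 to compound 3. Compound 3 is estimated at 25 mg/kg, with an expected range from 8 mg/kg to 60 mg/kg.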

Compound 3, dose for half-maximal effect: > 20 mg/kg
Compound 3: a limit, no number (the forecaster's own chance of this, stated with the estimate: 65%); the middle value is on the limit's open side.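

In this assay compound 3 gives > 20 mg/kg, again a limit and not a number, so its steps from compound 1 and from compound 2 cannot be read. The results now rest on one limit: the limit of > 20 mg/kg in this assay, at which 3 of the 3 values shown sit. The compounds shown leave open what number compound 1, compound 2 or compound 3 would take, and whether these side-chain changes shift the dose at all.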